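This account rests on a few compounds, and the source may have more. Where it says the series, first, only, none or still open, it means among the compounds named here.

Measured so far:
compound 1 `ClCc1ccccc1Cn1cnc2ncnc(Cl)c21` — 42700 nM
compound 2 `ClCc1ccc(Cn2cnc3ncnc(Cl)c32)cc1` — 40700 nM

In a functional assay on SN12C cells (Homo sapiens) for cytotoxicity, read by sulforhodamine B assay, with a stated time of 48 h (a lower number here means that less compound is tolerated, a higher number that more compound is tolerated), compound 1 gives 42700 nM. Compound 2, the second of the two, gives 40700 nM in this assay. Compound 2 carries the lowest of the two numbers, but the gap to compound 1 lies within the scatter, so the two compounds read as equivalent on this read-out; there is no ordering to draw from them.

Compound 3 `ClCc1ccc(Cn2cnc3nc(Cl)nc(Cl)c32)cc1` has not yet been measured in this assay. It differs from compound 2 by chloro in place of hydrogen on an aromatic carbon, the chloro entering on the ring carbon that sits between two ring nitrogen atoms of the shared core. Going by the values given here, no step between measured compounds is available, so the size of this change is not anchored by anything; the step from compound 2 to compound 3 is expected to be small, most likely none beyond the scatter, with direction open.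

Compound 3 is therefore estimated at 30000 nM in this assay, with a range of 10000 nM to 90000 nM, which means an expected step of a 1.4-fold lower number from compound 2 to compound 3 (0.13 log units; within the scatter).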

Compound 3, concentration lethal to 50% of the cells: 6600 nM
Beside the measured number, compound 3's estimate is 4.5-fold (0.66 log units) above it; measured number below the stated range.
By their numbers in this assay, from the lowest: compound 3; then compounds 2 and 1 (each within the scatter of the next).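

In this assay, chloro in place of hydrogen on the aromatic carbon between two ring nitrogen atoms gives a 6.2-fold lower number from compound 2 to compound 3 (0.79 log units; beyond the scatter), so less compound is tolerated after this change. Compound 1 and compound 2 lie within the scatter of each other and gave no view of this carbon; it now proves able to move the read-out, and a change of one heavy atom, with no hydrogen-bond donor or acceptor entering, is enough for a step beyond the scatter. No measurement at hand accounts for the step.

Going by these compounds, whether the step belongs to chloro itself or would also appear with an amine, a methoxy group or a methyl group on this carbon remains open. Also open, on these data alone, is whether the same change on compound 1 gives a step of similar size.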